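This account rests on a few compounds, and the source may have more. Where it says the series, first, only, none or still open, it means among the compounds named here.

Of the compounds shown here, two sharing one core have so far been measured in an assay on CHO cells for displacement of a labelled ligand from adenosine receptor A1 (Homo sapiens); a higher number here means a weaker inhibitor, a lower number a stronger inhibitor. Compound 1 `CCCn1c(-c2ccco2)nc2c(N)ncnc21` gives 19 nM in this assay. Compound 2 `Cn1c(-c2ccco2)nc2c(N)ncnc21` gives 62 nM in this assay, the highest of the two numbers; its nearest neighbour is compound 1, and the step of a 3.3-fold higher number from compound 1 to compound 2 (0.51 log units; beyond the scatter) carries the change of hydrogen in place of ethyl on a saturated chain carbon bound to an aromatic nitrogen. Compound 3 `CCn1c(-c2ccco2)nc2c(N)ncnc21` has not yet been measured. It differs from compound 2 by methyl in place of hydrogen on a saturated chain carbon bound to an aromatic nitrogen, which, cut one bond further out, reads as methyl to ethyl. Within the data shown here, only one measured step bears on this change, namely a 3.3-fold higher number from compound 1 to compound 2 (0.51 log units; beyond the scatter), and it ran in the opposite direction over a larger change of the chain. Compound 3 sits between the two measured compounds in the size of that chain, so the step of a 2.1-fold lower number from compound 2 to compound 3 (0.32 log units; beyond the scatter) is expected to lower the number, by less than the full measured step. Compound 3 is therefore estimated at 30 nM in this assay, with a range from 15 nM to 60 nM.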

Compound 3, inhibition constant: 24 nM
For compound 3 the middle estimate is 1.3-fold (0.10 log units) above the measured one; the measured number falls inside the stated range.
By their numbers in this assay, from the lowest: compounds 1 and 3 (each within the scatter of the next); then compound 2.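

In this assay, the change of methyl to ethyl on the saturated chain bound to an aromatic nitrogen gives a 2.6-fold lower number from compound 2 to compound 3 (0.41 log units; beyond the scatter), so this single added carbon is enough for a step beyond the scatter. The further difference in the chain, read from the longer chain of compound 1 to the ethyl chain, gives a 1.3-fold higher number from compound 1 to compound 3 (0.10 log units; within the scatter), which means that compound 1 and compound 3 cannot be told apart here, and the gap first seen between compound 1 and compound 2 is matched by the methyl to ethyl change alone. No available evidence accounts for this uneven response to chain length.

The three compounds leave open whether the flat stretch continues with a longer chain such as butyl, or whether a branched chain such as isopropyl, a small ring such as cyclopropyl, or a chain ending in a hydroxyl or an amine would move the number in either direction. They also leave open whether the same methyl to ethyl step would hold on any core other than the shared one, or at any receptor other than this one.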